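This account rests on a few compounds, and the source may have more. Where it says the series, first, only, none or still open, it means among the compounds named here.

Measured compounds:
compound 1, `COc1ccc(-c2nc3cc(F)ccc3[nH]2)c(F)c1`, 1590 nM
compound 2, `COc1ccc(Br)cc1-c1nc2cc(F)ccc2[nH]1`, 2600 nM
compound 3, `COc1ccc(Br)cc1-c1nc2cc(Cl)ccc2[nH]1`, 2620 nM

All three were tested in an assay for inhibition of Alpha amylase (Homo sapiens), with a stated time of 10 min; on this read-out lower numbers stand for stronger inhibition and higher numbers for weaker inhibition. Compound 1 gives 1590 nM, compound 2 gives 2600 nM and compound 3 gives 2620 nM; the three numbers lie within the scatter of one another. The difference between the core of compound 1 and the core of compound 2 is not broken down here. Compound 3 differs from compound 2 by chloro in place of fluoro on an aromatic carbon, a change that produced a 1.0-fold higher number from compound 2 to compound 3 (0.00 log units; within the scatter). The unmeasured compound 4, `COc1ccc(-c2nc3cc(Cl)ccc3[nH]2)c(F)c1`, is related to compound 1 by the same change, (chloro in place of fluoro on an aromatic carbon), at the same place. Because the step from compound 2 to compound 3 was a 1.0-fold higher number from compound 2 to compound 3 (0.00 log units; within the scatter), compound 4 is expected to show a 1.0-fold higher number from compound 1 to compound 4 (0.00 log units; within the scatter), an expectation resting on that single matched pair. Compound 4 is estimated at 1600 nM in this assay.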

Compound 4, half-maximal inhibitory concentration: 2740 nM
For compound 4 the middle estimate is 1.7-fold (0.23 log units) below the measured one, within the range that was stated.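

In this assay, chloro in place of fluoro on an aromatic carbon gives a 1.7-fold higher number from compound 1 to compound 4 (0.24 log units; within the scatter). Set beside the earlier matched pair, the step reads alike on both cores: the same change on two cores in this assay, a 1.0-fold higher number (0.00 log units; within the scatter) from compound 2 to compound 3 and a 1.7-fold higher number (0.24 log units; within the scatter) from compound 1 to compound 4, 1.7-fold (0.23 log units) apart, within the scatter of two such steps. On these two cores the change carries over with no step beyond the scatter, but two pairs do not show that it would carry to other cores, nor do they give a reliable size for the change.

As far as these compounds go, only fluoro and chloro appear at this place, so an amine, a carboxylic acid or a longer chain there remains open. Also open, from the compounds shown here alone, is whether any group at this place would move the number beyond the scatter.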